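Swapping an aromatic ring for a cyclohexyloxy group

The source may hold more compounds than are shown below. What is called first, only, known or untested is meant among the compounds shown, and "the series" means these compounds.

Of the compounds shown here, three have been measured in a functional assay for inhibition of sodium/hydrogen exchanger (Oryctolagus cuniculus); on this read-out lower numbers stand for stronger inhibition and higher numbers for weaker inhibition. Compound 1 `CCN(CC)Cc1cc(Br)c(S(C)(=O)=O)cc1C(=O)N=C(N)N` gives 9500 nM, a weak result. Compound 2 `Cc1ccc(-c2ccc(C(=O)N=C(N)N)cc2S(C)(=O)=O)cc1` gives 100 nM, and compound 3 `Cc1cc(-c2ccc(Cl)cc2)c(S(C)(=O)=O)cc1C(=O)N=C(N)N` gives 45 nM, the lowest of the three numbers, so compound 3 is the strongest inhibitor measured so far; compound 2 comes nearest, while compound 1 lies furthest away, both gaps beyond the usual scatter.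

Compound 4 `Cc1cc(OC2CCCCC2)c(S(C)(=O)=O)cc1C(=O)N=C(N)N` has not yet been measured. It is derived from compound 3 by one structural change: cyclohexyloxy in place of 4-chlorophenyl on an aromatic carbon. Where compound 3 carried a second aromatic ring, compound 4 carries a saturated ring attached through an oxygen.

Within the data shown here, no single-change step between measured compounds exists to guide the expectation, so only a rough guess is possible. Both strong compounds, compound 2 and compound 3, have an aromatic ring at this place, and compound 4 gives that up, so some loss of potency is expected; the step from compound 3 to compound 4 is estimated at a 4.0-fold higher number from compound 3 to compound 4 (0.60 log units; beyond the scatter). For compound 4 in this assay, the expected value is 180 nM, with a range from 45 nM to 700 nM.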

Compound 4, half-maximal inhibitory concentration: 37 nM
Estimate against measurement, compound 4: 4.9-fold (0.69 log units) above; the measured number lies below the stated range.
By their numbers in this assay, from the lowest: compounds 4 and 3 (each within the scatter of the next); then compound 2; then compound 1.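

In this assay, putting cyclohexyloxy in place of 4-chlorophenyl gives a 1.2-fold lower number from compound 3 to compound 4 (0.09 log units; within the scatter), so the two groups cannot be told apart at this position, ortho to a methylsulfonyl group. Compound 3 alone could not show whether an aromatic ring was needed here; compound 4 shows that, with the rest of the molecule unchanged, a six-membered non-aromatic ring attached through an oxygen serves as well on this read-out. No measurement of any property of these two groups accompanies the result, so it stands as a plain observation about potency and offers no explanation.

The compounds shown leave open whether the saturated ring or the oxygen link matters more, a question that a cyclohexyl group attached directly to the aromatic carbon, or a phenoxy group with an aromatic ring on the same oxygen, could help to settle. They also leave open whether a ring is needed here at all, which a simple methoxy group or a short amine such as dimethylamino at the same place would begin to test.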